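The source may hold more compounds than are shown below. What is called first, only, known or untested is meant among the compounds shown, and "the series" means these compounds.

Compound 1, `CCOc1ccc(/C=C(/Sc2ccc(C)cc2)C(=O)c2ccc(Cl)cc2)cc1OC`: 25000 nM in a functional assay on DU-145 cells (Homo sapiens) for inhibition, read by trypan blue exclusion, with a stated time of 96 h; a lower number here means a stronger inhibitor of growth, a higher number a weaker inhibitor of growth
Compound 2, `CSc1ccc(/C=C(\C(=O)c2ccc(Cl)cc2)S(=O)(=O)Cc2ccc(Cl)cc2)cc1`: 10000 nM
Compound 3, `COc1cc(OC)c(/C=C(/SCc2ccc(Cl)cc2)C(=O)c2ccc(Br)cc2)c(OC)c1`: 1000 nM

Among these three, compound 1 has the highest number and so is the weakest inhibitor of growth. Compound 2 sits nearest to it, with a lower number that is still beyond the scatter, while compound 3 lies furthest away, with a far lower number.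

Compound 4, `CCOc1ccc(/C=C(\C(=O)c2ccc(Cl)cc2)S(=O)(=O)Cc2ccc(C)cc2)cc1OC`, differs from compound 1 in one place: (4-methylbenzyl)sulfonyl in place of (4-methylphenyl)sulfanyl on a double-bonded chain carbon bound to a carbonyl carbon and a double-bonded chain carbon. For the measured compounds named here, no measured pair here separates exactly this change, so its size is open. Compound 2, which carries a sulfonyl attached through a single chain carbon to its aromatic ring, gives 10000 nM, the closer of the two lower numbers. On that basis a modest step toward a lower number is expected from compound 1 to compound 4, a 2.1-fold lower number from compound 1 to compound 4 (0.32 log units; beyond the scatter), though one that may not clear the scatter. Compound 4 is estimated at 12000 nM, within a range from 4000 nM to 40000 nM.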

Compound 4, concentration for 50% growth inhibition: 10000 nM
Compound 4: middle estimate off by 1.2-fold (0.08 log units), on the high side; the range from low to high includes it.
By their numbers in this assay, from the lowest: compound 3; then compounds 2 and 4 (each within the scatter of the next); then compound 1.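

In this assay, for the compounds shown here, placing (4-methylbenzyl)sulfonyl on this double-bonded chain carbon gives a 2.5-fold lower number from compound 1 to compound 4 (0.40 log units; beyond the scatter), the first step in this set that follows a change in one place only. The step is modest but beyond the scatter, so this position takes the group with more heavy atoms and growth inhibition gets somewhat stronger, not weaker. Nothing measured here explains the shift.

The change alters two things at once, sulfanyl to sulfonyl and phenyl to benzyl, so the step cannot be divided between them. A (4-methylbenzyl)sulfanyl or (4-methylphenyl)sulfonyl group at this place would separate the two, and an amine there would show whether the number depends on having sulfur at this position at all.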